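A ring swap on the amide of compound 2

The compounds below may be only part of what the source reports. "The series", "measured", "known", "first", "only" and "open" are said of these compounds alone.

Compound 1 `CN(C)C(=O)c1ccncc1Nc1cc(-c2ccc3ccn(C)c3c2)c2nccnc2c1` measures 175 ug/mL
Compound 2 `CC(=O)N1CCOC(CNC(=O)c2ccncc2Nc2cc(-c3ccc4ccn(C)c4c3)c3nccnc3c2)C1` measures 268 ug/mL

Both numbers come from a physicochemical assay for solubility, read by spectrophotometry, measured as kinetic solubility, at pH 8, tested at 500 uM (on this read-out lower numbers stand for lower solubility and higher numbers for higher solubility), and the two compounds cannot be told apart, since compound 2 stands level with compound 1 within the scatter. Among the measured compounds shown here, the only measured step is a 1.5-fold higher number from compound 1 to compound 2 (0.19 log units; within the scatter) and it put ((4-acetylmorpholin-2-yl)methyl)amino in place of dimethylamino on a carbonyl carbon.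

Compound 3 `CC(=O)N1CC(NC(=O)c2ccncc2Nc2cc(-c3ccc4ccn(C)c4c3)c3nccnc3c2)C1` has not been measured yet. It differs from compound 2 in one place, on an amide-type nitrogen (1-acetylazetidin-3-yl in place of (4-acetylmorpholin-2-yl)methyl on an amide-type nitrogen). A six-membered non-aromatic ring gives way to a four-membered non-aromatic ring, and an acetyl group is present on both sides of the change.

For the measured compounds named here, no measured step makes this exact swap, so the evidence is thin. Going by compound 2 and its step of a 1.5-fold higher number from compound 1 to compound 2 (0.19 log units; within the scatter) at this same amide, no change beyond the scatter is expected in this assay for this swap. The estimated change is a 1.3-fold lower number from compound 2 to compound 3 (0.11 log units; within the scatter) and it stays inside the scatter. Compound 3 is expected at 210 ug/mL with an estimated range from 120 ug/mL to 290 ug/mL until a measurement exists.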

Compound 3, solubility: 244 ug/mL
Estimate against measurement, compound 3: 1.2-fold (0.07 log units) below; low and high end bracket the measured number.
By their numbers in this assay, from the lowest: compounds 1, 3 and 2 (each within the scatter of the next).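

In this assay, replacing (4-acetylmorpholin-2-yl)methyl with 1-acetylazetidin-3-yl on the amide-type nitrogen gives a 1.1-fold lower number from compound 2 to compound 3 (0.04 log units; within the scatter) even though the group shrinks from 10 heavy atoms to 7 and the six-membered ring with 2 hetero atoms becomes a four-membered ring with 1 hetero atom. Against the small dimethylamino starting point, (1-acetylazetidin-3-yl)amino gives a 1.4-fold higher number from compound 1 to compound 3 (0.14 log units; within the scatter) and so, like the morpholine group, does not separate from it in this read-out: this position has now taken two differently sized acetylated rings with no change beyond the scatter. Nothing available here explains why these readings stay level and the comparison rests on single numbers for three compounds.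

Both rings carry an acetyl group, so the compounds shown leave open what the same rings would give with a free ring amine in place of the acetylated nitrogen. They also leave open whether a different group on this amide nitrogen, such as a carboxylic acid or a longer chain ending in an amine, would move the number beyond the scatter.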